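Swapping 2-methoxyphenyl for 4-hydroxyphenyl on the shared core

This account rests on a few compounds, and the source may have more. Where it says the series, first, only, none or still open, it means among the compounds named here.

In a functional assay on SW-620 cells (Homo sapiens) for cytotoxicity, read by MTT assay, with a stated time of 72 h (on this read-out lower numbers stand for stronger inhibition and higher numbers for weaker inhibition), compound 1 (`COc1ccc(/C=C2\CCC/C(=C\c3ccccc3Br)C2=O)cc1OC`) gives 5300 nM and compound 2 (`COc1ccccc1/C=C1\CCC/C(=C\c2ccc(OC)c(OC)c2)C1=O`) gives 7800 nM on the same shared core. For the measured compounds named here, these are the only two numbers so far. Compound 2 sits within the scatter of compound 1, so neither can be ranked above the other. Compound 3 (`COc1ccc(/C=C2\CCC/C(=C\c3ccc(O)cc3)C2=O)cc1OC`) has not yet been measured. Its structure departs from compound 2 as follows: 4-hydroxyphenyl in place of 2-methoxyphenyl on a double-bonded chain carbon bound to a double-bonded ring carbon. Going by the values given here, only one measured step bears on this change: methoxy in place of bromo on an aromatic carbon, in the same aromatic group that now leaves. Because that single change gave a 1.5-fold higher number from compound 1 to compound 2 (0.17 log units; within the scatter) no shift beyond the scatter is expected in this assay for the new swap. Among the compounds with values here, no measured compound carries a hydroxy group, so this guide is indirect. The expected size is a 1.3-fold lower number from compound 2 to compound 3 (0.11 log units; within the scatter) with wide uncertainty in either direction. Compound 3 is therefore expected at 6000 nM with 2000 nM to 16000 nM as the estimated range.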

Compound 3, half-maximal inhibitory concentration: 7700 nM
For compound 3 the middle estimate is 1.3-fold (0.11 log units) below the measured one, and the stated range covers the measured number.
By their numbers in this assay, from the lowest: compounds 1, 3 and 2 (each within the scatter of the next).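

In this assay the step at this place, on a double-bonded chain carbon bound to a double-bonded ring carbon, is a 1.0-fold lower number from compound 2 to compound 3 (0.01 log units; within the scatter) and the matching step from the bromine-bearing group is a 1.5-fold higher number from compound 1 to compound 3 (0.16 log units; within the scatter), so 2-bromophenyl, 2-methoxyphenyl and 4-hydroxyphenyl cannot be told apart here. The earlier compounds had only shown an exchange of methoxy and bromo within one aromatic group, whereas this result extends the comparison to a different group, 4-hydroxyphenyl, which brings a hydrogen-bond donor to this place and still leaves the number within the scatter of the other two. No measured information explains why the three numbers stay so close.

Going by these compounds, all three compounds carry a substituted phenyl group at this place, so it remains open whether a group of another kind there, such as an amine or a carboxylic acid, would move the number beyond the scatter. On these data alone, the rest of the shared core is the same in all three compounds, so it is also open whether this insensitivity would hold with a different group on the other side of the core.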